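The source may report more compounds than this note shows. Statements on the series, on what has been measured and on what is new or still open speak of the compounds shown alone.

In a functional assay on the whole organism (strain Kunming) with Mus musculus as the target, with a stated time of 0.5 h (on this read-out higher numbers stand for an effect only at larger amounts of compound and lower numbers for an effect already at smaller amounts), compound 1 (`COc1ccccc1/C=C/C(=O)OC/C=C/c1cc(OC)c(OC)cc1OC`) gives 625 umol/kg after the stated time. Two relatives were read in the same way: compound 2 (`COc1cc(OC)c(OC)cc1/C=C/COC(=O)/C=C/c1c(OC)ccc(OC)c1OC`) gives 476 umol/kg and compound 3 (`COc1cc(OC)c(OC)cc1/C=C/COC(=O)/C=C/c1ccc(OC)c(OC)c1OC`) gives 456 umol/kg on the same read-out. All three values lie within the usual scatter of one another, so compound 1 stands level with the other two and none of them can be told apart.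

Compound 4 (`COc1cc(OC)c(OC)cc1/C=C/COC(=O)/C=C/c1ccccc1Cl`) departs from compound 1 in one place (chloro in place of methoxy on an aromatic carbon). The swap sits on an aromatic carbon of a six-membered aromatic ring of carbon only, ortho to a large group, and turns 2-methoxyphenyl into 2-chlorophenyl. Among the compounds with values here, no measured pair shows this single change on its own, and no measured compound carries the chloro group, so the data offer no direct guide.

The only support is the narrow spread of the measured set, with compound 1 at 625 umol/kg and compound 3 at 456 umol/kg within the scatter of each other. No change beyond the scatter is expected in either direction, and the estimated step (a 1.3-fold lower number from compound 1 to compound 4 (0.11 log units; within the scatter)) is small. For compound 4 the expected value is 480 umol/kg with an estimated range from 220 umol/kg to 900 umol/kg in this assay.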

Compound 4, dose for half-maximal effect: 385 umol/kg
The estimate for compound 4 lay 1.2-fold (0.10 log units) above the measured number, within the range that was stated.
By their numbers in this assay, from the lowest: compounds 4, 3, 2 and 1 (each within the scatter of the next).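

Within the data shown here, the first direct reading at this place is the step from the methoxy group to chloro on an aromatic carbon ortho to a large group, a 1.6-fold lower number from compound 1 to compound 4 (0.21 log units; within the scatter) in this assay, and it stays within the scatter. The earlier compounds shown here all carried methoxy groups on this ring, so they could not show that 2-methoxyphenyl can give way to 2-chlorophenyl, with a hydrogen-bond acceptor leaving and a single chlorine entering, without a change that can be told from the scatter. No information is available on why this exchange leaves the read-out level, and this single pair sets no trend for other groups at this place.

As far as these compounds go, what remains open is whether an amine, a carboxylic acid or a longer chain such as an ethoxy or butoxy group on this same aromatic carbon would shift the dose beyond the scatter in either direction. The compounds shown also leave open whether the phenyl ring needs any group at this place at all, as a plain hydrogen there would show.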